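Two Ring Stereocentres Inverted in Compound 1

This account rests on a few compounds, and the source may have more. Where it says the series, first, only, none or still open, it means among the compounds named here.

In an ADME assay on the whole organism for pharmacokinetics, with Rattus norvegicus as the target, at a dose of 3 mg/kg by the oral route (a lower number here means that a smaller share of the oral dose reaches the circulation, a higher number that a larger share of the oral dose reaches the circulation), compound 1 (`COC(=O)N[C@H](C(=O)N1CCC[C@H]1C(=O)Nc1ccc([C@H]2CC[C@H](c3ccc(NC(=O)[C@@H]4CCCN4C(=O)[C@@H](NC(=O)OC)C(C)(C)C)cc3)N2c2ccc(F)cc2)cc1)C(C)(C)C`) gives 39%, while compound 2 (`COC(=O)N[C@H](C(=O)N1CCC[C@H]1C(=O)Nc1ccc([C@@H]2CC[C@@H](c3ccc(NC(=O)[C@@H]4CCCN4C(=O)[C@@H](NC(=O)OC)[C@H]4CCOC4)cc3)N2c2ccc(F)cc2)cc1)[C@H]1CCOC1`) gives 1.5%. Within the data shown here, compound 1 therefore holds the higher of the two numbers so far, and the gap lies beyond the usual scatter.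

Compound 3 (`COC(=O)N[C@H](C(=O)N1CCC[C@H]1C(=O)Nc1ccc([C@@H]2CC[C@@H](c3ccc(NC(=O)[C@@H]4CCCN4C(=O)[C@@H](NC(=O)OC)C(C)(C)C)cc3)N2c2ccc(F)cc2)cc1)C(C)(C)C`) has not yet been measured. Its difference from compound 1 is purely one of configuration: the two compounds have the same atoms and bonds and differ only in configuration as drawn: 2 of 6 stereo elements differ; a stereocentre at a saturated ring carbon is drawn R in compound 1 and S in compound 3; a stereocentre at a saturated ring carbon is drawn R in compound 1 and S in compound 3. Among the measured compounds shown here, no measured pair isolates such a change, so the data offer no direct guide to its size or direction. The expectation therefore starts from compound 1 at 39%, and no step beyond the scatter is expected in this assay, though with a slight lean downward. The estimated step is a number 9 percentage points lower from compound 1 to compound 3 (within the scatter). For compound 3 the expected oral bioavailability is 30%, within an estimated range of 10% to 55%.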

Compound 3, oral bioavailability in the Rattus norvegicus assay: 23%
For compound 3 the middle estimate is 7 percentage points above the measured one; the range from low to high includes it.
By their numbers in the Rattus norvegicus assay, from the lowest: compound 2; then compound 3; then compound 1.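

Inverting the two saturated ring stereocentres is enough on its own to shift oral exposure: in the Rattus norvegicus assay compound 1 gives 39% and compound 3 gives 23%, and the change is a number 16 percentage points lower from compound 1 to compound 3 (beyond the scatter). In a physicochemical assay for solubility, in phosphate buffer, measured as kinetic solubility, at pH 7.2 (on this read-out lower numbers stand for lower solubility and higher numbers for higher solubility), compound 1 gives 3900 nM and compound 3 gives 4400 nM, and the same inversion gives a 1.1-fold higher number from compound 1 to compound 3 (0.05 log units; within the scatter), so the two compounds stand level on solubility, and this read-out does not follow the shift in oral exposure. Among these compounds, no earlier measured pair isolated configuration, and this step can be assigned to it alone because of how the pair is related: the fact that compounds 1 and 3 differ only in the configuration as drawn.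

The compounds shown leave open how much of the step belongs to each of the two stereocentres, as they appear here only inverted together. From the compounds shown here alone, it also stays open whether the same inversion would give a similar step with an amine or a carboxylic acid in place of the fluorine.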